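This account rests on a few compounds, and the source may have more. Where it says the series, first, only, none or still open, it means among the compounds named here.

Working notes on the series. Among the measured compounds shown here, in a functional assay for agonist activity at G protein-coupled receptor 88 (Homo sapiens), read by HTRF and cAMP accumulation (on this read-out lower numbers stand for an effect already at smaller amounts and higher numbers for an effect only at larger amounts of compound), compound 1 `CC[C@H](C)[C@@H](CN(C(=O)[C@@H]1C[C@H]1c1ccccc1)c1ccc(-c2ccccc2)cc1)NC(C)=O` gives 5.8 nM, and compound 2 `CCC(C)CNCCN(C(=O)[C@@H]1C[C@H]1c1ccccc1)c1ccc(-c2ccccc2)cc1` gives 4.7 nM; the change a 1.2-fold lower number from compound 1 to compound 2 (0.09 log units; within the scatter) is the only single-point step measured so far. Compound 3 `CC[C@H](C)[C@H](N)CN(C(=O)[C@@H]1C[C@H]1c1ccc(Cl)cc1)c1ccc(-c2ccccc2)cc1` gives 4300 nM and stands with the highest number of the three, far from compound 1 and compound 2, which differ from it in more than one place, so the cause of that gap is not resolved.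

Compound 4 `CC[C@H](C)[C@H](N)CN(C(=O)[C@@H]1C[C@H]1c1cccc(C)c1)c1ccc(-c2ccccc2)cc1` is compound 3 with 3-methylphenyl in place of 4-chlorophenyl on a saturated ring carbon. For the measured compounds named here, no measured step touches the aryl group on the three-membered ring: the one measured step concerns the side chain on the amide-type nitrogen and lies within the scatter, so it carries no information on this change. The expectation for compound 4 therefore rests on compound 3 alone, with a step of a 1.1-fold lower number from compound 3 to compound 4 (0.03 log units; within the scatter) estimated in this assay, that is, none beyond the scatter, and a wide range to cover the lack of precedent. Compound 4 is estimated at 4000 nM, with a range from 1200 nM to 14000 nM.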

Compound 4, half-maximal effective concentration: 1200 nM
The estimate for compound 4 lay 3.3-fold (0.52 log units) above the measured number; measured number inside the range.
By their numbers in this assay, from the lowest: compounds 2 and 1 (each within the scatter of the next); then compound 4; then compound 3.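

In this assay, the aryl group on the saturated ring carbon of the three-membered ring proves sensitive to change: 3-methylphenyl in place of 4-chlorophenyl gives a modest step (a 3.6-fold lower number from compound 3 to compound 4 (0.55 log units; beyond the scatter)). Among the compounds shown here, this is the first single-point step beyond the scatter, as the earlier one concerned the side chain on the amide-type nitrogen and stayed within it. Substituent and ring position change together here, so the step cannot be assigned to either, and no supporting data explain its size.

The compounds shown leave open whether 4-methylphenyl or 3-chlorophenyl at this place would separate the two changes. They also leave open whether an unsubstituted phenyl with the same free amine side chain would account for any of the gap between compounds 3 and 4 and compounds 1 and 2.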